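From trifluoromethyl to fluoro in the series

The source may hold more compounds than are shown below. What is called first, only, known or untested is meant among the compounds shown, and "the series" means these compounds.

Compound 1 `COC(=O)C1=C(C)N=C(C)/C(=C(\O)OC)C1c1ccccc1N`: 39800 nM
Compound 2 `COC(=O)C1=C(C)N=C(C)/C(=C(\O)OC)C1c1ccc(F)cc1`: 129 nM
Compound 3 `COC(=O)C1=C(C)N=C(C)/C(=C(\O)OC)C1c1ccccc1C(F)(F)F`: 1.51 nM

In a functional assay (muscle tissue) with Cavia porcellus as the target (on this read-out lower numbers stand for an effect already at smaller amounts and higher numbers for an effect only at larger amounts of compound), compound 3 gives 1.51 nM, the lowest of the three numbers. The next compound to consider is compound 4 `COC(=O)C1=C(C)N=C(C)/C(=C(\O)OC)C1c1ccccc1F`, which has fluoro in place of trifluoromethyl on an aromatic carbon. For the measured compounds named here, two measured steps bear on this change, and both are large. The first is a 26000-fold lower number from compound 1 to compound 3 (4.42 log units; beyond the scatter), with trifluoromethyl in place of amino on an aromatic carbon. The second is a 310-fold lower number from compound 1 to compound 2 (2.49 log units; beyond the scatter), with 4-fluorophenyl in place of 2-aminophenyl. Neither step tests fluoro on the carbon it occupies in compound 4, so the evidence is indirect. Compound 2 also carries fluoro, and its value of 129 nM lies well above that of compound 3, which points to a higher number for compound 4. The expected change is a moderate rise beyond the scatter, smaller than either measured step, and is estimated as a 13-fold higher number from compound 3 to compound 4 (1.12 log units; beyond the scatter). For compound 4 the estimated value is 20 nM, with an expected range of 4 nM to 100 nM.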

Compound 4, half-maximal effective concentration: 42.7 nM
The estimate for compound 4 lay 2.1-fold (0.33 log units) below the measured number; measured number inside the range.
By their numbers in this assay, from the lowest: compound 3; then compound 4; then compound 2; then compound 1.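

Read directly on this aromatic carbon, ortho to a large group, in this assay fluoro in place of trifluoromethyl gives a 28-fold higher number from compound 3 to compound 4 (1.45 log units; beyond the scatter), so the low number of compound 3 does not carry over to the smaller fluoro group. Moving fluoro around the phenyl gives a 3.0-fold lower number from compound 2 to compound 4 (0.48 log units; beyond the scatter), a modest step but beyond the scatter, which shows that the position of fluoro matters in this assay. Fluoro in place of amino gives a 930-fold lower number from compound 1 to compound 4 (2.97 log units; beyond the scatter), so on this carbon the order from the lowest number is trifluoromethyl, fluoro, amino.

Nothing available accounts for these differences. Open, as far as these compounds go, is where chloro, methyl or nitrile on this aromatic carbon would fall relative to compound 3 and compound 4.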